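A Fluorobenzyl Swap and Its Expected Solubility

The source may report more compounds than this note shows. Statements on the series, on what has been measured and on what is new or still open speak of the compounds shown alone.

Compound 1 `CNC(=O)c1cc(C(=O)NC2CC2)cn([C@H](C)c2ccccc2)c1=O` was tested in a physicochemical assay for solubility (on this read-out lower numbers stand for lower solubility and higher numbers for higher solubility), and gave >= 168 ug/mL, which is a limit of the assay rather than a number, (the limit of >= 168 ug/mL in this assay, at which 1 of the 3 values shown sits). Compound 3 `CNC(=O)c1ccc(=O)n(Cc2ccccc2)c1` likewise sits at a limit in this assay, giving >= 108 ug/mL, (the limit of >= 108 ug/mL in this assay, at which 1 of the 3 values shown sits). Compound 2 `CNC(=O)c1cc(C(=O)NCCC(C)C)cn(Cc2ccccc2)c1=O`, by contrast, gives 10 ug/mL in this assay. Where compound 1 stands is thus known only as a limit, and no step between measured compounds that differ in one place is available. Compound 4 `CNC(=O)c1cc(C(=O)NC2CC2)cn(Cc2ccccc2F)c1=O` carries 2-fluorobenzyl in place of 1-phenylethyl on an aromatic nitrogen. For the measured compounds named here, with no measured step to rest on, the expected change is an at least 1.5-fold lower number from compound 1 to compound 4 (0.18 log units; that floor lies within the scatter), small and plausibly within the scatter. Compound 4 is estimated to give 110 ug/mL, between 35 ug/mL and 250 ug/mL.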

Compound 4, solubility: >= 145 ug/mL
Compound 4 ended at the assay's limit; the forecaster's own chance of this, stated with the estimate: 40%; middle value at least 1.3-fold (0.11 log units) away from the limit.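

The step from compound 1 to compound 4 cannot be read, since both compounds stand at limits of this assay rather than at numbers. From the compounds shown here alone, how far 2-fluorobenzyl in place of 1-phenylethyl shifts the read-out, and in which direction, stays open.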